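Swapping the carbamate-bearing piperazine for a plain piperidine

A few compounds are considered here, and "the series" means these few. Any claim that something is new, unique, unknown or untested is made for them only; others in the source may bear on it.

Compound 1 `CCOC(=O)N1CCN(/[N+]([O-])=N/Oc2cc(O/N=[N+](\[O-])N(C)C)c([N+](=O)[O-])cc2[N+](=O)[O-])CC1` stands lowest of the three numbers measured in a functional assay on HL-60 cells (Homo sapiens) for antiproliferative activity, read by MTT assay, with a stated time of 72 h (a lower number here means a stronger inhibitor of growth, a higher number a weaker inhibitor of growth), where compound 1 gives 2000 nM. Compound 2 `CCCCOC(=O)N1CCN(/[N+]([O-])=N/Oc2cc(O/N=[N+](\[O-])N(C)C)c([N+](=O)[O-])cc2[N+](=O)[O-])CC1` gives 2700 nM in this assay, and compound 3 `CN(C)/[N+]([O-])=N/Oc1cc(O/N=[N+](\[O-])N2CCN(c3ncccn3)CC2)c([N+](=O)[O-])cc1[N+](=O)[O-]` gives 5000 nM. The step of a 1.4-fold higher number from compound 1 to compound 2 (0.13 log units; within the scatter) lies within the scatter, whereas a 2.5-fold higher number from compound 1 to compound 3 (0.40 log units; beyond the scatter) is a modest change beyond it.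

Compound 4 `CN(C)/[N+]([O-])=N/Oc1cc(O/N=[N+](\[O-])N2CCCCC2)c([N+](=O)[O-])cc1[N+](=O)[O-]` differs from compound 1 in one place: piperidin-1-yl in place of 4-(ethoxycarbonyl)piperazin-1-yl on a double-bonded nitrogen. The closest precedents are the steps at the same ring nitrogen, a 2.5-fold higher number from compound 1 to compound 3 (0.40 log units; beyond the scatter) and a 1.9-fold higher number from compound 2 to compound 3 (0.27 log units; within the scatter), both of which moved the number upward when the ethoxycarbonyl or butoxycarbonyl group was exchanged. Among the compounds with values here, the present change goes further, since the ring itself loses its second nitrogen and the carbonyl altogether, and no measured step covers that. A modest rise in this assay is therefore expected, in the order of a 1.8-fold higher number from compound 1 to compound 4 (0.24 log units; within the scatter). Compound 4 is estimated at 3500 nM, with a likely range from 1500 nM to 8000 nM.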

Compound 4, concentration for total growth inhibition: 4900 nM
Estimate against measurement, compound 4: 1.4-fold (0.15 log units) below, within the range that was stated.
By their numbers in this assay, from the lowest: compounds 1, 2, 4 and 3 (each within the scatter of the next, the first and the last beyond it).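

In this assay, replacing 4-(ethoxycarbonyl)piperazin-1-yl with piperidin-1-yl on the double-bonded nitrogen gives a 2.5-fold higher number from compound 1 to compound 4 (0.39 log units; beyond the scatter), a modest step beyond the scatter. This is the first step shown in which the ring itself changes, and the smaller group carries neither the carbonyl nor the second ring nitrogen. Compound 3 gives 5000 nM and compound 4 gives 4900 nM, values within the scatter of each other, so a pyrimidin-2-yl group on the piperazine and the plain piperidine ring end up at the same level, and neither matches compound 1.

The compounds shown leave open whether a morpholine ring, a piperazine with a free amine or a carboxylic acid on the ring would bring the number back down. Nothing measured here bears on what lies behind the rise.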